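This account rests on a few compounds, and the source may have more. Where it says the series, first, only, none or still open, it means among the compounds named here.

Measured in a functional assay on KOPN-8 cells (Homo sapiens) for antiproliferative activity, with a stated time of 72 h; a higher number here means that more compound is needed for the effect, a lower number that less compound is needed:
- Compound 1 `COc1ccc(-c2cc(=O)c3c(OC)cc(OC)cc3n2C)cc1`: 30000 nM
- Compound 2 `C=CCNC(=O)n1c(-c2ccc(OC)cc2)cc(=O)c2c(OC)cc(OC)cc21`: 12000 nM
- Compound 3 `COc1ccc(-c2cc(=O)c3c(OC)cc(OC)cc3n2S(=O)(=O)c2ccc(C=O)cc2)cc1`: > 34400 nM (a limit of the assay, not a number)

Compound 3 has no number of its own and stands at the limit of > 34400 nM in this assay, at which 1 of the 3 values shown sits. Compound 4 `COc1ccc(-c2cc(=O)c3c(OC)cc(OC)cc3n2S(=O)(=O)c2ccc(C)c([N+](=O)[O-])c2)cc1` has not yet been measured in this assay. It carries 4-methyl-3-nitrophenyl in place of 4-formylphenyl on a sulfonyl sulfur.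

For the measured compounds named here, no measured step changes the group at this place, so the evidence is indirect. All three measured steps are exchanges on the aromatic nitrogen. They are a 2.5-fold lower number from compound 1 to compound 2 (0.40 log units; beyond the scatter), an at least 1.1-fold higher number from compound 1 to compound 3 (0.05 log units; that floor lies within the scatter) and an at least 2.8-fold higher number from compound 2 to compound 3 (0.45 log units; beyond the scatter). These steps replace the whole substituent on that nitrogen and are modest in size where their size is known. The change to compound 4 keeps the sulfonyl group on the aromatic nitrogen and alters only the aryl group on the sulfur. A step beyond the scatter in this assay is therefore not expected, and no direction can be favoured. Compound 4 may well reach a limit of the assay too.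

For compound 4 the estimated value is 30000 nM, with an expected range from 10000 nM to 60000 nM. The expected step is an at least 1.1-fold lower number from compound 3 to compound 4 (0.05 log units; that floor lies within the scatter).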

Compound 4, half-maximal effective concentration: > 51700 nM
Compound 4: a limit, no number; the forecaster's own chance of this, stated with the estimate: 50%; middle value at least 1.7-fold (0.23 log units) from the limit.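

Compound 4 gives > 51700 nM, which is a limit of the assay and not a number. Compound 3 gives > 34400 nM, likewise a limit, so no step can be read from compound 3 to compound 4. The compounds shown leave open whether 4-methyl-3-nitrophenyl or 4-formylphenyl on a sulfonyl sulfur gives the lower number.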